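Dimethylamino in place of 3,3-dimethylazetidin-1-yl on a carbonyl carbon

The compounds below may be only part of what the source reports. "The series", "measured", "known", "first", "only" and "open" are said of these compounds alone.

Measured in an ADME assay on MDCKII-LE cells (Canis lupus familiaris) for permeability; on this read-out lower numbers stand for lower permeability and higher numbers for higher permeability:
Compound 1 `Cc1cnc(NC(=O)c2cc(Oc3cnc(C(=O)N(C)C)nc3)c3cc(C)oc3c2)cn1`: 20.1 10^-6 cm/s
Compound 2 `Cc1ccc(Oc2cc(C(=O)Nc3cnc(C)cn3)cc3oc(C)cc23)cc1`: 0.3 10^-6 cm/s
Compound 3 `Cc1cc2c(Oc3cnc(C(=O)N4CC(C)(C)C4)cn3)cc(C(=O)Nc3cnccn3)cc2o1`: 7.7 10^-6 cm/s

Compound 3 gives 7.7 10^-6 cm/s, compound 1 gives 20.1 10^-6 cm/s and compound 2 gives 0.3 10^-6 cm/s. Compound 3 thus stands second of the three, with compound 1 higher and compound 2 lower. Both gaps lie beyond the scatter. Compound 4 `Cc1cc2c(Oc3cnc(C(=O)N(C)C)cn3)cc(C(=O)Nc3cnccn3)cc2o1` has not yet been measured. It departs from compound 3 by one change: dimethylamino in place of 3,3-dimethylazetidin-1-yl on a carbonyl carbon. Among the compounds with values here, no measured pair shows this change directly. Compound 1 also carries dimethylcarbamoyl and gives 20.1 10^-6 cm/s, but it differs from compound 4 elsewhere as well, so it offers only a loose guide. The expected step is small and upward, within the scatter, a 1.6-fold higher number from compound 3 to compound 4 (0.19 log units; within the scatter). For compound 4 the estimated value is 12 10^-6 cm/s, with an expected range of 5.5 10^-6 cm/s to 24 10^-6 cm/s.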

Compound 4, apparent permeability: 30 10^-6 cm/s
Beside the measured number, compound 4's estimate is 2.5-fold (0.40 log units) below it; the whole stated range lies below it.
By their numbers in this assay, from the lowest: compound 2; then compound 3; then compounds 1 and 4 (each within the scatter of the next).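

In this assay, dimethylamino in place of 3,3-dimethylazetidin-1-yl on the carbonyl carbon gives a 3.9-fold higher number from compound 3 to compound 4 (0.59 log units; beyond the scatter), a modest step beyond the scatter. Within the data shown here, this is the first direct reading of this change, and it shows that the read-out at this place depends on which amine group the carbonyl carbon carries. Nothing measured here explains the rise.

As far as these compounds go, it remains open whether a plain azetidine, a pyrrolidine or a morpholine on the same carbonyl carbon would read nearer compound 3 or compound 4. Also open, from the compounds shown here alone, is whether the step would hold on the core of compound 1.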